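Series notes: from compound 3 to compound 4

A few compounds are considered here, and "the series" means these few. Any claim that something is new, unique, unknown or untested is made for them only; others in the source may bear on it.

In a physicochemical assay for solubility, at pH 7.4 (on this read-out higher numbers stand for higher solubility and lower numbers for lower solubility), compound 1 `O=C(c1cccnc1)N1CCC(NS(=O)(=O)c2cc(S(=O)(=O)c3ccccc3)ccc2C(F)(F)F)CC1` gives 78000 nM, compound 2 `O=C(c1ccc(Cl)nc1)N1CCC(NS(=O)(=O)c2cc(S(=O)(=O)c3ccccc3)ccc2C(F)(F)F)CC1` gives 1700 nM, and compound 3 `CN(C)c1ccc(C(=O)N2CCC(NS(=O)(=O)c3cc(S(=O)(=O)c4ccccc4)ccc3C(F)(F)F)CC2)cn1` gives 6700 nM, the second highest of the three numbers. Compound 4 `O=C(O)c1cccc(S(=O)(=O)N2CCC(NS(=O)(=O)c3cc(S(=O)(=O)c4ccccc4)ccc3C(F)(F)F)CC2)c1` differs from compound 3 on an amine nitrogen in a ring: (3-carboxyphenyl)sulfonyl in place of (6-(dimethylamino)pyridin-3-yl)carbonyl on an amine nitrogen in a ring. For the measured compounds named here, no measured step covers this exchange. The closest are changes on an aromatic carbon of the group that leaves: a 12-fold lower number from compound 1 to compound 3 (1.07 log units; beyond the scatter), which is large, and a 3.9-fold higher number from compound 2 to compound 3 (0.60 log units; beyond the scatter), which is modest. A large step to a higher number is expected, though its direction rests on the structural change alone. The expected step is a 7.5-fold higher number from compound 3 to compound 4 (0.87 log units; beyond the scatter). The estimate for compound 4 is 50000 nM, with a range of 10000 nM to 200000 nM.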

Compound 4, solubility: > 100000 nM
Compound 4: no number, only a limit (the forecaster's own chance of this, stated with the estimate: 20%); middle value at least 2.0-fold (0.30 log units) from the limit.
By their numbers in this assay, from the lowest: compound 2; then compound 3; then compound 1. At a limit, above all of these: compound 4.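

In this assay compound 4 gives > 100000 nM, a limit of the assay and not a number. The earlier compounds shown here differed only on an aromatic carbon of the acyl group, whereas this exchange on the amine nitrogen in a ring gives an at least 14-fold higher number from compound 3 to compound 4 (1.17 log units; beyond the scatter), an at least 58-fold higher number from compound 2 to compound 4 (1.76 log units; beyond the scatter) and an at least 1.2-fold higher number from compound 1 to compound 4 (0.10 log units; that floor lies within the scatter). The last of these steps cannot be read, as its floor lies within the scatter.

The exchange alters both the carbonyl and the ring substituent, so the compounds shown leave open which part carries the steps. A plain phenylsulfonyl group, or a benzoyl group bearing the carboxylic acid, on the same nitrogen would separate the two.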